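Benzyloxy to hydroxy in the series of compound 2

The source may hold more compounds than are shown below. What is called first, only, known or untested is meant among the compounds shown, and "the series" means these compounds.

Measured in a functional assay on A549 cells (Homo sapiens) for antiproliferative activity, read by MTT assay, with a stated time of 48 h; a higher number here means a weaker inhibitor, a lower number a stronger inhibitor:
compound 1 `O=c1cc(-c2ccccc2)oc2cc(O)c(OCCCCN3CCCCC3)c(O)c12` gives 75000 nM
compound 2 `O=c1cc(-c2ccccc2)oc2cc(OCc3ccccc3)c(OCCCN3CCCC3)c(O)c12` gives 1400 nM
compound 3 `CN(C)CCCOc1c(OCc2ccccc2)cc2oc(-c3ccccc3)cc(=O)c2c1O` gives 2600 nM

Compound 2 sits with compound 3 at the low end of these numbers, and compound 1 lies far higher. Among the compounds with values here, the one measured step, a 1.9-fold higher number from compound 2 to compound 3 (0.27 log units; within the scatter), stays within the scatter, but it concerns the amine end of the chain and does not bear directly on the next change.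

Unmeasured compound 4 `O=c1cc(-c2ccccc2)oc2cc(O)c(OCCCN3CCCC3)c(O)c12` departs from compound 2 by hydrogen in place of benzyl on an oxygen on an aromatic ring, or benzyloxy to hydroxy. Within the data shown here, no measured step isolates this change. Among the measured compounds shown here, compound 1, the only measured compound with hydroxy there, gives 75000 nM, but its chain also differs, so this evidence is indirect. A clear rise in this assay is expected, probably short of the value of compound 1. The expected size is an 11-fold higher number from compound 2 to compound 4 (1.03 log units; beyond the scatter). For compound 4 the estimated value is 15000 nM, with an expected range of 4000 nM to 60000 nM.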

Compound 4, half-maximal inhibitory concentration: > 100000 nM
Compound 4: no number, only a limit; the forecaster's own chance of this, stated with the estimate: 5%; at least 6.6-fold (0.82 log units) between middle value and limit.
By their numbers in this assay, from the lowest: compounds 2 and 3 (each within the scatter of the next); then compound 1. At a limit, above all of these: compound 4.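

Within the series of compound 2, benzyloxy to hydroxy with the chain and amine held constant is a large change: an at least 71-fold higher number from compound 2 to compound 4 (1.85 log units; beyond the scatter). This isolates the loss of activity to the group on this oxygen on an aromatic ring, which compound 1 could not do, as its chain also differs. In this assay compound 4 gives > 100000 nM, which is a limit and not a number.

The two hydroxy compounds cannot be put in order, and an at least 1.3-fold higher number from compound 1 to compound 4 (0.12 log units; that floor lies within the scatter) says nothing firm about the amine end when hydroxy is present. The compounds shown cover only benzyl and hydrogen on this oxygen, so it remains open whether a smaller ether such as methyl, or a substituted benzyl such as 4-fluorobenzyl, would keep the values of the benzyloxy compounds.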